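This account rests on a few compounds, and the source may have more. Where it says the series, first, only, none or still open, it means among the compounds named here.

Of the compounds shown here, three sharing one core have been measured in a toxicity assay on GES1 cells (Homo sapiens) for inhibition, read by MTT assay, with a stated time of 72 h; on this read-out lower numbers stand for stronger inhibition and higher numbers for weaker inhibition. Compound 1 `Cc1cc(N2CC[C@@H](C)[C@@H](N(C)c3ncnc4[nH]ccc34)C2)n2nc(SCC3CC3)nc2n1` gives 27900 nM. Compound 2 `Cc1cc(N2CC[C@@H](C)[C@@H](N(C)c3ncnc4[nH]ccc34)C2)n2nc(SCc3nc4ccccc4[nH]3)nc2n1` gives 40200 nM. Compound 3 `Cc1cc(N2CC[C@@H](C)[C@@H](N(C)c3ncnc4[nH]ccc34)C2)n2nc(SCc3ccc([N+](=O)[O-])cc3)nc2n1` gives 36600 nM. The three numbers lie together: the step of a 1.4-fold higher number from compound 1 to compound 2 (0.16 log units; within the scatter) and the step of a 1.3-fold higher number from compound 1 to compound 3 (0.12 log units; within the scatter) are both within the scatter, as is the step of a 1.1-fold lower number from compound 2 to compound 3 (0.04 log units; within the scatter), so compound 2 cannot be set apart from compound 1 or compound 3 on these numbers.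

Compound 4 `C#CSc1nc2nc(C)cc(N3CC[C@@H](C)[C@@H](N(C)c4ncnc5[nH]ccc45)C3)n2n1` is now to be measured in this assay. It differs from compound 2 in one place: ethynyl in place of (1H-benzimidazol-2-yl)methyl on a sulfur. The measured steps that bear on this are the exchanges on the saturated chain carbon bound to the sulfur, namely a 1.4-fold higher number from compound 1 to compound 2 (0.16 log units; within the scatter) and a 1.1-fold lower number from compound 2 to compound 3 (0.04 log units; within the scatter), each within the scatter. None of them removes that chain carbon or places an ethynyl directly on the sulfur, so the new change is only partly covered. Given that the three varied groups at this end of the molecule left the numbers within the scatter of one another, compound 4 is expected to stay near them, with the step of a 1.1-fold lower number from compound 2 to compound 4 (0.06 log units; within the scatter) expected not to exceed the scatter. The estimate for compound 4 in this assay is 35000 nM, within a range from 15000 nM to 80000 nM.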

Compound 4, half-maximal inhibitory concentration: > 100000 nM
Compound 4: only a limit was reported (the forecaster's own chance of this, stated with the estimate: 15%); middle value at least 2.8-fold (0.45 log units) away from the limit.
By their numbers in this assay, from the lowest: compounds 1, 3 and 2 (each within the scatter of the next). At a limit, above all of these: compound 4.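

In this assay compound 4 is reported only as a limit, > 100000 nM, so its true value is not known. Even so, this limit gives an at least 2.4-fold higher number from compound 2 to compound 4 (0.39 log units; beyond the scatter), an at least 2.7-fold higher number from compound 3 to compound 4 (0.43 log units; beyond the scatter) and an at least 3.5-fold higher number from compound 1 to compound 4 (0.55 log units; beyond the scatter), each beyond the scatter. The earlier exchanges on the saturated chain carbon bound to the sulfur left the numbers within the scatter of one another, whereas ethynyl directly on the sulfur stands apart from all three compounds on the side of weaker inhibition, so this position is not indifferent to every change.

The compounds shown cannot say whether the loss of the chain carbon, the loss of the larger group or the arrival of the triple bond accounts for this, since compound 4 differs from the others in all of these at once. A propargyl group on the sulfur, which keeps a saturated chain carbon and carries a triple bond, and a plain methyl on the sulfur, which has neither a ring nor a triple bond, would be the groups to separate these readings.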